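Swapping the amide partner on a shared core

The source may report more compounds than this note shows. Statements on the series, on what has been measured and on what is new or still open speak of the compounds shown alone.

Compound 2 `Nc1nn(CC(=O)NCc2ccco2)c2nc(-c3ccccc3)cc(C(F)(F)F)c12` has the lowest number of the two compounds measured in a functional assay on HeLa cells (Homo sapiens) for cytotoxicity, read by MTT assay, with a stated time of 24 h (a higher number here means a weaker inhibitor, a lower number a stronger inhibitor), where compound 2 gives 7100 nM. Its nearest neighbour is compound 1 `CCNC(=O)Cn1nc(N)c2c(C(F)(F)F)cc(-c3ccccc3)nc21`, which in this assay gives 20200 nM; the step of a 2.8-fold lower number from compound 1 to compound 2 (0.45 log units; beyond the scatter) came from putting furan-2-yl in place of methyl on a saturated chain carbon bound to an amide-type nitrogen. Compound 3 `Nc1nn(CC(=O)N2CCCCC2)c2nc(-c3ccccc3)cc(C(F)(F)F)c12` differs from compound 2 at a different point: piperidin-1-yl in place of ((furan-2-yl)methyl)amino on a carbonyl carbon. For the measured compounds named here, no measured step shares this change, so the single step from compound 1 to compound 2 only shows that the amide partner matters at this position on the core of compound 2. With the furan-2-yl group removed, the number for compound 3 is expected to move back toward that of compound 1, giving an estimated step of a 1.7-fold higher number from compound 2 to compound 3 (0.23 log units; within the scatter). Compound 3 is therefore estimated at 12000 nM, within a range from 4000 nM to 35000 nM.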

Compound 3, half-maximal inhibitory concentration: 2900 nM
For compound 3 the middle estimate is 4.1-fold (0.62 log units) above the measured one; measured number outside the range, below it.
By their numbers in this assay, from the lowest: compound 3; then compound 2; then compound 1.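

Putting piperidin-1-yl in place of ((furan-2-yl)methyl)amino on the carbonyl carbon lowers the number in this assay (a 2.4-fold lower number from compound 2 to compound 3 (0.39 log units; beyond the scatter)), and putting it in place of ethylamino lowers the number further (a 7.0-fold lower number from compound 1 to compound 3 (0.84 log units; beyond the scatter)). The furan-2-yl group is therefore not required for a low number at this position: compound 3 lacks it, and has the lowest number of the three compounds. Unlike ((furan-2-yl)methyl)amino, piperidin-1-yl also carries no hydrogen-bond donor, but no measurement shown here explains why this change lowers the number.

The compounds shown leave open whether the lower number goes with the ring or with the missing amide hydrogen. A dimethylamino partner has no amide hydrogen and no ring, a cyclohexylamino partner has a ring and keeps that hydrogen, and comparing these two with compound 3 could separate the two features.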